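The compounds below may be only part of what the source reports. "The series", "measured", "known", "first", "only" and "open" are said of these compounds alone.

Measured so far in a functional assay on HT-29 cells (Homo sapiens) for cytotoxicity, read by MTT assay, with a stated time of 72 h; a lower number here means a stronger inhibitor of growth, a higher number a weaker inhibitor of growth:

Compound 1 `CCCCC[Se]c1nc(NCc2ccc(SC)cc2)c2ccccc2n1`: in this assay compound 1 gives > 100000 nM, which is a limit of the assay.
Compound 2 `CSc1ccc(CNc2nc([SeH])nc3ccccc23)cc1`: in this assay compound 2 gives > 100000 nM, again a limit.
Compound 3 `CSc1ccc(CNc2nc(SC)nc3ccccc23)cc1`: in this assay compound 3 gives > 100000 nM, also a limit.

Compound 3 therefore stands nowhere on a scale of numbers; it sits at the same place as the other two, (the limit of > 100000 nM in this assay, at which 3 of the 3 values shown sit). The steps from compound 1 to compound 3 a step that the two limits leave unreadable from compound 1 to compound 3 and from compound 2 to compound 3 a step that the two limits leave unreadable from compound 2 to compound 3 are both unreadable, as is the step from compound 1 to compound 2 a step that the two limits leave unreadable from compound 1 to compound 2, so no change at this carbon of the shared core has yet produced a readable number.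

Compound 4 `CSc1ccc(CNc2nc([Se]C)nc3ccccc23)cc1` is the next member: a group of 2 heavy atoms (1 carbon, 1 selenium; no ring) in place of a group of 2 heavy atoms (1 carbon, 1 sulfur; no ring), on an aromatic carbon. Among the measured compounds shown here, the steps that bear on it are those from compound 1 and compound 2 to compound 3, and both are unreadable in size. For the measured compounds named here, no step in this assay suggests a move off the limit, so compound 4 is expected to behave like compound 3. The expected step that the limit leaves unreadable from compound 3 to compound 4 is accordingly put at none beyond the scatter. Compound 4 is estimated at 200000 nM, with a range from 100000 nM to 1000000 nM, and most likely it will again be reported only as a limit.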

Compound 4, concentration for total growth inhibition: > 100000 nM
Compound 4: no number, only a limit; the forecaster's own chance of this, stated with the estimate: 85%; the middle value lies beyond the limit too.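

No step among compound 1, compound 2, compound 3 and compound 4 can be read in this assay, since each compound stays at a limit: the limit of > 100000 nM in this assay, at which 4 of the 4 values shown sit.

The compounds shown leave open whether any group on this aromatic carbon of the shared core gives a readable number in this assay, and how sulfur- and selenium-linked groups compare there.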